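This account rests on a few compounds, and the source may have more. Where it says the series, first, only, none or still open, it means among the compounds named here.

Of the compounds shown here, three from this series have been measured in a functional assay on T47D cells (Homo sapiens) for inhibition, read by sulforhodamine B assay, with a stated time of 72 h; on this read-out higher numbers stand for weaker inhibition of growth and lower numbers for stronger inhibition of growth. Compound 1, `O=S(=O)(Nc1cc(-c2cnc3[nH]cc(-c4ccncc4)c3c2)cnc1Cl)c1ccccc1F`, gives 1790 nM. Compound 2, `O=S(=O)(Nc1cc(-c2cnc3[nH]ncc3c2)cnc1Cl)c1ccccc1`, gives 4400 nM. Compound 3, `O=S(=O)(Nc1cc(-c2cnc3[nH]cc(-c4ccccc4)c3c2)cnc1Cl)c1ccccc1`, gives 7720 nM. Among these three numbers compound 2 holds the second highest place: the gap between compound 2 and compound 3 is within the scatter of this assay and allows no ordering, while compound 1 sits beyond the scatter with the lower number, meaning stronger inhibition of growth.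

Compound 4, `O=S(=O)(Nc1cc(-c2cnc3[nH]nc(-c4ccncc4)c3c2)cnc1Cl)c1ccccc1`, has not yet been measured. It differs from compound 2 in one place: pyridin-4-yl in place of hydrogen on an aromatic carbon. Among the measured compounds shown here, no measured pair in this set shows exactly this change, so the size of the step must be judged without a direct precedent. For the measured compounds named here, compound 1 also carries a pyridin-4-yl group, though on a different core and with a different sulfonamide, and it is the one compound with a number beyond the scatter on the lower side, which gives a weak hint that the added group could help. The expectation for the step from compound 2 to compound 4 is therefore a modest fall, a 1.8-fold lower number from compound 2 to compound 4 (0.25 log units; within the scatter), though it may well stay within the scatter. Compound 4 is estimated at 2500 nM, with a plausible range from 800 nM to 8000 nM in this assay.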

Compound 4, concentration for 50% growth inhibition: 520 nM
Compound 4: middle estimate off by 4.8-fold (0.68 log units), on the high side; the whole stated range lies above it.
By their numbers in this assay, from the lowest: compound 4; then compound 1; then compounds 2 and 3 (each within the scatter of the next).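

In this assay, putting pyridin-4-yl in place of hydrogen on this aromatic carbon of the five-membered ring gives an 8.5-fold lower number from compound 2 to compound 4 (0.93 log units; beyond the scatter), so the position accepts a group of this size and the change strengthens inhibition of growth. Among the compounds shown here, this is also the first reading of a single change: the earlier compounds differed from one another in more than one place, so the contribution of this group could not be separated from the other differences. Nothing available here accounts for the gain, as no measurement bears on why the group has this effect.

As far as these compounds go, whether the gain depends on the ring nitrogen of the added group stays open, and a phenyl ring on this same carbon of the shared core would address that directly. Also open, from the compounds shown here alone, is whether a much smaller group, such as a methyl or an amine, would have a similar effect at this position, and whether the step would keep its size with a different group on the sulfonamide.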